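Removing the succinate ester from compound 2

The source may hold more compounds than are shown below. What is called first, only, known or untested is meant among the compounds shown, and "the series" means these compounds.

Compound 1 `Cc1c(C)c2c(c(C)c1OC(=O)CCC(=O)NC1CC(C)(C)N([O])C(C)(C)C1)CC[C@@](C)(CCC[C@H](C)CCC[C@H](C)CCCC(C)C)O2` | > 300000 nM
Compound 2 `Cc1c(C)c2c(c(C)c1OC(=O)CCC(=O)O)CCC(C)(C(=O)NC1CC(C)(C)N([O])C(C)(C)C1)O2` | > 300000 nM

In a functional assay on MCF7 cells (Homo sapiens) for cytotoxicity, read by MTT assay, with a stated time of 72 h (a lower number here means a stronger inhibitor, a higher number a weaker inhibitor), compound 1 gives > 300000 nM as a limit of the assay and not as a number. Compound 2 gives > 300000 nM as a limit too. It therefore stands at the limit of > 300000 nM in this assay, at which 2 of the 2 values shown sit, and offers no number to start from.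

The change from compound 2 to compound 3 `Cc1c(C)c2c(c(C)c1O)CCC(C)(C(=O)NC1CC(C)(C)N([O])C(C)(C)C1)O2` is hydrogen in place of (2-carboxyethyl)carbonyl on an oxygen on an aromatic ring and, cut one bond further out, reads ((2-carboxyethyl)carbonyl)oxy to hydroxy. For the measured compounds named here, no measured pair shows what this change does. A small move towards stronger inhibition in this assay is expected, with an at least 1.5-fold lower number from compound 2 to compound 3 (0.17 log units; that floor lies within the scatter) as the estimate. That expectation starts from compound 2 with its > 300000 nM limit, so it is loose, and another reading at the limit remains quite possible. For compound 3 the estimated value is 200000 nM with an expected range from 50000 nM to 400000 nM as the likely span.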

Compound 3, half-maximal inhibitory concentration: 58000 nM
Estimate against measurement, compound 3: 3.4-fold (0.54 log units) above; the range from low to high includes it.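

Replacing (2-carboxyethyl)carbonyl with hydrogen on an oxygen on an aromatic ring gives, in this assay, an at least 5.1-fold lower number from compound 2 to compound 3 (0.71 log units; beyond the scatter). Compound 3, which carries hydroxy at this place, is the only compound shown that gives a number rather than a limit, so this position does affect the read-out, and the change lies beyond the scatter. The step gives only a floor and not a full size, because compound 2 stands at a limit: the limit of > 300000 nM in this assay, at which 2 of the 3 values shown sit.

The compounds shown leave open whether the lower number comes from the free hydroxy itself or from the loss of this particular ester, which an acetyl group or a methyl ether on the same oxygen would help to separate. Also open, from the compounds shown here alone, is whether a shorter or longer acid chain at this place would read like compound 2 or like compound 3.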